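Compound 4: one more amide in a level series

A few compounds are considered here, and "the series" means these few. Any claim that something is new, unique, unknown or untested is made for them only; others in the source may bear on it.

Of the compounds shown here, three sharing one core have been tested in a functional assay on KBVIN cells (Homo sapiens) for antiproliferative activity, read by sulforhodamine B assay, with a stated time of 3 days; on this read-out higher numbers stand for weaker inhibition of growth and lower numbers for stronger inhibition of growth. Compound 1 `O=C(Nc1ccccn1)c1cccc(Nc2ncc(F)c(Nc3ccc(F)cc3)n2)c1` gives 13700 nM, compound 2 `COc1ccc(NC(=O)c2cccc(Nc3ncc(F)c(Nc4ccc(F)cc4)n3)c2)cc1` gives 15700 nM, and compound 3 `O=C(Nc1cccc(Nc2ncc(F)c(Nc3ccc(F)cc3)n2)c1)c1cnccn1` gives 20100 nM. Compound 3 is not separated from the other two: the gaps are a 1.5-fold higher number from compound 1 to compound 3 (0.17 log units; within the scatter) and a 1.3-fold higher number from compound 2 to compound 3 (0.11 log units; within the scatter), and repeat measurements of one compound can differ as much.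

Compound 4 `O=C(c1cccc(Nc2ncc(F)c(Nc3ccc(F)cc3)n2)c1)N1CCCCC1` has not been measured yet. It carries (piperidin-1-yl)carbonyl in place of ((pyrazin-2-yl)carbonyl)amino on an aromatic carbon.

The closest evidence comes from the same place on the molecule. There, (pyridin-2-yl)carbamoyl and (4-methoxyphenyl)carbamoyl were compared with the group that compound 4 loses, and the gaps stayed within the scatter. The exchange between those two carbamoyl groups, a 1.1-fold higher number from compound 1 to compound 2 (0.06 log units; within the scatter), was just as small. Going by these compounds, none of the three tested compounds has a non-aromatic ring at this place, however, so the new ring is untested and the margin must stay wide.

No change beyond the scatter is therefore expected in this assay. The expected step is a 1.3-fold lower number from compound 3 to compound 4 (0.10 log units; within the scatter). For compound 4 the estimated value is 16000 nM, with an expected range of 8000 nM to 32000 nM.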

Compound 4, concentration for 50% growth inhibition: 13800 nM
Compound 4: middle estimate off by 1.2-fold (0.06 log units), on the high side; the measured number falls inside the stated range.
By their numbers in this assay, from the lowest: compounds 1, 4, 2 and 3 (each within the scatter of the next).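

Compound 4 brings the first non-aromatic ring to this place, and in this assay nothing separates it from the earlier amides: a 1.5-fold lower number from compound 3 to compound 4 (0.16 log units; within the scatter), a 1.1-fold lower number from compound 2 to compound 4 (0.06 log units; within the scatter), and a 1.0-fold higher number from compound 1 to compound 4 (0.00 log units; within the scatter). It also differs from them in a second way, since the nitrogen of its amide carries no hydrogen, whereas compounds 1, 2 and 3 each keep the amide hydrogen; among these four compounds, then, neither an aromatic ring on the amide nor that hydrogen is needed for the number to stay in this range. The data shown offer no measurement that would account for this level result.

Going by these compounds, all four compounds still carry an amide with a six-membered ring at this place, so it remains open whether a group of another kind, such as a carboxylic acid, a free amine or a short alkyl chain, would move the number beyond the scatter. The shared core also stays the same throughout, so what a change to its two fluorine atoms would do in this assay cannot be told from these compounds.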